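This account rests on a few compounds, and the source may have more. Where it says the series, first, only, none or still open, it means among the compounds named here.

Measured so far:
- compound 1 `O=c1cc(-c2cccc([N+](=O)[O-])c2)oc2ccccc12` — 2 ug/mL
- compound 2 `COc1c(OC)c(OC)c2c(=O)cc(-c3ccc(OC(C)=O)cc3)oc2c1OC` — 3 ug/mL

Both compounds were tested in a functional assay on KB cells (Homo sapiens) for cytotoxicity; a lower number here means that less compound is needed, a higher number that more compound is needed for the effect. Compound 1 gives 2 ug/mL there, and compound 2 gives 3 ug/mL. These two numbers lie within the usual scatter of repeated measurements, so the two compounds cannot be set apart from each other on this evidence; compound 1 simply shows one of two closely spaced values.

The next compound, compound 3 `CS(=O)(=O)Oc1cccc(-c2cc(=O)c3ccccc3o2)c1`, is built from compound 1 by a single change on one aromatic carbon: (methylsulfonyl)oxy in place of nitro on an aromatic carbon. The compound keeps everything else of compound 1.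

Within the data shown here, no pair of measured compounds differs in only one place, so there is no measured step on which to rest an expectation of size. Only the two closely spaced values above are known. For compound 3 the step from compound 1 is expected to be a 1.5-fold higher number from compound 1 to compound 3 (0.18 log units; within the scatter), that is, no shift beyond the scatter or at most a modest rise in the number. Compound 3 is therefore estimated at 3 ug/mL, with a range from 1 ug/mL to 9 ug/mL.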

Compound 3, concentration for half-maximal effect: > 100 ug/mL
Compound 3: a limit, no number; the forecaster's own chance of this, stated with the estimate: 5%; at least 33-fold (1.52 log units) between middle value and limit.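

In this assay, among these compounds, the earlier compounds gave two closely spaced values but no single change to read, whereas this pair shows that the group on this aromatic carbon, meta to a large group, can decide the result: (methylsulfonyl)oxy in place of nitro gives an at least 50-fold higher number from compound 1 to compound 3 (1.69 log units; beyond the scatter), with the rest of the molecule unchanged. So a swap between two uncharged groups without a hydrogen-bond donor can still separate two compounds far beyond the scatter, and counting those features does not predict the outcome here. Compound 3 gives a limit of the assay, > 100 ug/mL, and not a number, so the step has a known minimum but no known full size, and it is the only limit among the values shown: the limit of > 100 ug/mL in this assay, at which 1 of the 3 values shown sits.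

From the compounds shown here alone, what stays open is whether nitro is unusually favourable at this position or (methylsulfonyl)oxy is unusually unfavourable, since one step cannot separate these two readings. A compound carrying an amine, a methoxy group or a plain hydrogen on the same carbon would show which reading holds, and the compounds shown include none of these.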